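The compounds below may be only part of what the source reports. "The series", "measured", "known", "first", "only" and "open" are said of these compounds alone.

Of the compounds shown here, three sharing one core have been measured in an ADME assay on a cell-free system (plasma, Homo sapiens) for protein binding; on this read-out higher numbers stand for a larger free fraction and lower numbers for a smaller free fraction: compound 1 (`Cc1cc2ncccc2cc1Nc1ncc2c(n1)n(C1CCN(C)CC1)c(=O)n2C`) gives 0.56, compound 2 (`Cc1cc2ncccc2cc1Nc1ncc2c(n1)n(C1CCNCC1)c(=O)n2C`) gives 0.68 and compound 3 (`Cc1cc2ncccc2cc1Nc1ncc2c(n1)n([C@H]1CCN(C)C1)c(=O)n2C`) gives 0.67. Compound 3 sits level with the other two, within the scatter of both, as a 1.0-fold lower number from compound 2 to compound 3 (0.01 log units; within the scatter) shows. Compound 4 (`Cc1cc2ncccc2cc1Nc1ncc2c(n1)n([C@H]1CCN(C3COC3)C1)c(=O)n2C`) carries oxetan-3-yl in place of methyl on an amine nitrogen in a ring. The closest evidence is the change on such a nitrogen, a 1.2-fold higher number from compound 1 to compound 2 (0.08 log units; within the scatter), along with the ring change, a 1.2-fold higher number from compound 1 to compound 3 (0.08 log units; within the scatter). For the measured compounds named here, neither goes beyond the scatter, but no measured compound carries oxetan-3-yl. In this assay, the expected result is therefore no change beyond the scatter, with an estimated 1.1-fold lower number from compound 3 to compound 4 (0.05 log units; within the scatter). For compound 4, the estimated value is 0.6, with an expected range of 0.38 to 0.82.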

Compound 4, unbound fraction in the Homo sapiens assay: 0.56
Estimate against measurement, compound 4: 1.1-fold (0.03 log units) above; low and high end bracket the measured number.
By their numbers in the Homo sapiens assay, from the lowest: compounds 1, 4, 3 and 2 (each within the scatter of the next).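

In the Homo sapiens assay, oxetan-3-yl on this amine nitrogen is level with methyl, a 1.2-fold lower number from compound 3 to compound 4 (0.08 log units; within the scatter). The 1-(oxetan-3-yl)pyrrolidin-3-yl group is also level with the two piperidine-bearing groups, a 1.2-fold lower number from compound 2 to compound 4 (0.08 log units; within the scatter) and no change at the digits printed from compound 1 to compound 4 (within the scatter). The same change does register in a physicochemical assay for lipophilicity, read by HPLC, using the shake flask method, measured as octanol-water partition, at pH 7.4; on this read-out higher numbers stand for higher lipophilicity and lower numbers for lower lipophilicity: the measured distribution coefficient of compound 3, 1.1, and of compound 4, 1.5, a number 0.40 log units higher (beyond the scatter) In the physicochemical assay, compound 3 gives 1.1 and compound 4 gives 1.5.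

The compounds shown leave open whether a cyclobutyl group or a 2-methoxyethyl chain on this nitrogen would give the same readings, which would separate the ring of oxetan-3-yl from its oxygen. They also leave open how oxetan-3-yl behaves on the nitrogen of the piperidin-4-yl group.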